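The source may hold more compounds than are shown below. What is called first, only, known or untested is meant among the compounds shown, and "the series" means these compounds.

Working notes on the series in a functional assay on HepG2 cells (Homo sapiens) for antiproliferative activity, read by MTT assay, with a stated time of 48 h; on this read-out higher numbers stand for weaker inhibition and lower numbers for stronger inhibition: compound 1 (`O=C(/C=C/c1cn(S(=O)(=O)c2ccc([N+](=O)[O-])cc2)c2ccccc12)c1ccncc1`) gives 18300 nM, compound 2 (`COc1ccc(S(=O)(=O)n2cc(/C=C/C(=O)c3ccncc3)c3ccccc32)cc1`) gives 26000 nM and compound 3 (`CCCS(=O)(=O)n1cc(/C=C/C(=O)c2ccncc2)c2ccccc21`) gives 46200 nM. Compound 4 (`O=C(/C=C/c1cn(S(=O)(=O)c2ccc(Cl)cc2Cl)c2ccccc12)c1ccncc1`) has 2,4-dichlorophenyl in place of propyl on a sulfonyl sulfur. Among the measured compounds shown here, two steps bear on this, each putting propyl in place of a substituted phenyl: a 2.5-fold higher number from compound 1 to compound 3 (0.40 log units; beyond the scatter) and a 1.8-fold higher number from compound 2 to compound 3 (0.25 log units; within the scatter). Compound 3 thus stands apart from compound 1 only. Read in reverse, these steps suggest a modest fall in the number in this assay, although no chlorinated compound has been measured. The expected change is a 2.1-fold lower number from compound 3 to compound 4 (0.32 log units; beyond the scatter). Compound 4 is estimated at 22000 nM, with an expected range of 10000 nM to 45000 nM.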

Compound 4, half-maximal inhibitory concentration: 14800 nM
For compound 4 the middle estimate is 1.5-fold (0.17 log units) above the measured one; the measured number falls inside the stated range.
By their numbers in this assay, from the lowest: compounds 4, 1, 2 and 3 (each within the scatter of the next, the first and the last beyond it).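

A second aryl group on the sulfonyl sulfur, this one chlorinated, now stands clear of propyl in this assay with a 3.1-fold lower number from compound 3 to compound 4 (0.49 log units; beyond the scatter) for 2,4-dichlorophenyl in place of propyl. It does not separate from the other aryl groups, with a 1.8-fold lower number from compound 2 to compound 4 (0.24 log units; within the scatter) and a 1.2-fold lower number from compound 1 to compound 4 (0.09 log units; within the scatter) as its steps, and compound 2 remains the exception to any reading of aryl over propyl. Nothing at hand explains these steps. Still open, on these data alone, is how a longer chain in place of propyl, or an amine or carboxylic acid on the phenyl ring, would behave at this sulfur.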